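The source may report more compounds than this note shows. Statements on the series, on what has been measured and on what is new or still open speak of the compounds shown alone.

Measured so far in a functional assay on NUGC-3 cells (Homo sapiens) for cytotoxicity, read by sulforhodamine B assay, tested at 10 uM; on this read-out higher numbers stand for more inhibition at the one concentration tested (going by the name of the read-out) and lower numbers for less inhibition:
compound 1, `CCCc1cc(-c2cn([C@H]3C[C@H](OC(C)=O)[C@@H](COC(C)=O)O3)c(=O)[nH]c2=O)on1`: 89.1%
compound 2, `CC(=O)OC[C@H]1O[C@@H](n2cc(-c3cn(Cc4ccc(C(C)C)cc4)nn3)c(=O)[nH]c2=O)C[C@@H]1OC(C)=O`: 95.4%

Compound 1 stands at the lower of the two numbers, but the gap to compound 2 lies within the scatter, so no difference between the two can be claimed; both give strong inhibition at the single concentration tested. Compound 3, `CC(=O)OC[C@H]1O[C@@H](n2cc(-c3cc(-c4ccccc4)no3)c(=O)[nH]c2=O)C[C@@H]1OC(C)=O`, has not been measured in this assay. It differs from compound 1 in one place: phenyl in place of propyl on an aromatic carbon. For the measured compounds named here, no step between measured compounds carries this kind of change, so the data give no measured size for it. With both measured compounds near the top of the range, the expected step in this assay is a number 0.9 percentage points higher from compound 1 to compound 3 (within the scatter), which is nothing beyond the scatter in either direction. Compound 3 is therefore estimated at 90%, with a range from 76% to 98%.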

Compound 3, a percentage reported as inhibition, at one concentration (the size of the read-out at that concentration, not a potency): 87.6%
Beside the measured number, compound 3's estimate is 2.4 percentage points above it; the measured number falls inside the stated range.
By their numbers in this assay, from the lowest: compounds 3, 1 and 2 (each within the scatter of the next).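

On the 3-propyl-1,2-oxazol-5-yl group, the aromatic carbon next to the ring nitrogen now has its first measured step: in this assay, phenyl in place of propyl gives a number 1.5 percentage points lower from compound 1 to compound 3 (within the scatter), so no difference between the two groups can be claimed. This position therefore accepts either the open propyl chain or a six-membered aromatic ring of carbon only, with strong inhibition kept at the one concentration tested. Nothing available explains this result or ties it to any property of either group.

As far as these compounds go, whether an amine, a carboxylic acid or a longer chain at this position would keep the inhibition remains open. From the compounds shown here alone, with only one concentration tested, it also remains open whether phenyl and propyl would separate in a measure of potency.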